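A Second Methoxy, on the Sulfonyl-Bearing Ring

A few compounds are considered here, and "the series" means these few. Any claim that something is new, unique, unknown or untested is made for them only; others in the source may bear on it.

Compound 1 `COc1cc(Nc2nc3ccccc3nc2S(=O)(=O)c2ccccc2)cc(OC)c1` and compound 2 `COc1cc(Nc2nc3ccccc3nc2S(=O)(=O)c2ccccc2)cc(OC)c1OC` share one core and differ by a single methoxy group. In a functional assay on HL-60 cells (Homo sapiens) for cytotoxicity, read by MTT assay, with a stated time of 72 h (a lower number here means a stronger inhibitor, a higher number a weaker inhibitor), compound 1 gives 50 nM, and compound 2 gives 1770 nM, the higher of the two numbers, with a 35-fold higher number from compound 1 to compound 2 (1.55 log units; beyond the scatter). Compound 3 `COc1ccc(S(=O)(=O)c2nc3ccccc3nc2Nc2cc(OC)c(OC)c(OC)c2)cc1` carries yet another methoxy, now elsewhere: methoxy in place of hydrogen on an aromatic carbon. Within the data shown here, the only measured step concerns a methoxy on a different ring, so it bears just loosely on this change. A step within the scatter or a modest rise is expected, a 1.1-fold higher number from compound 2 to compound 3 (0.05 log units; within the scatter). Compound 3 is therefore estimated at 2000 nM, within 600 nM to 7000 nM.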

Compound 3, half-maximal inhibitory concentration: 680 nM
Estimate against measurement, compound 3: 2.9-fold (0.47 log units) above, and the stated range covers the measured number.
By their numbers in this assay, from the lowest: compound 1; then compound 3; then compound 2.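

Changing phenylsulfonyl to (4-methoxyphenyl)sulfonyl gives a 2.6-fold lower number from compound 2 to compound 3 (0.42 log units; beyond the scatter), so a methoxy in place of hydrogen on this ring lowers the number. The same kind of swap on the other aromatic ring went the opposite way and by more, with a 35-fold higher number from compound 1 to compound 2 (1.55 log units; beyond the scatter), so the outcome of adding a methoxy depends on the ring that receives it. No available measurement explains this difference.

On these data alone, it remains open whether an amine or a carboxylic acid at this position would also lower the number. As far as these compounds go, whether the (4-methoxyphenyl)sulfonyl group would have a similar effect on compound 1 also remains open.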